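The compounds below may be only part of what the source reports. "The series", "measured", "known", "first", "only" and "open" are said of these compounds alone.

Measured so far in an ADME assay on HepG2 cells (Homo sapiens) for inhibition, with a stated time of 72 h; on this read-out higher numbers stand for an effect only at larger amounts of compound and lower numbers for an effect already at smaller amounts:
Compound 1, `C=C(C)C(=O)Nc1cccc(-c2nc3ccccc3s2)c1`, gives > 25000 nM, which is a limit of the assay and not a number.
Compound 2, `O=C(Nc1cccc(-c2nc3ccccc3s2)c1)c1cccnc1Cl`, gives > 25000 nM, again a limit.
Compound 3, `O=C(Nc1cccc(-c2nc3ccccc3s2)c1)c1ccc(Cl)nc1Cl`, gives > 25000 nM, again a limit.

Compound 1 therefore stands only at a limit, and every value shown sits at the limit of > 25000 nM in this assay, at which 3 of the 3 values shown sit. Compound 4, `O=C(Nc1cccc(-c2nc3ccccc3s2)c1)c1ccncc1Cl`, differs from compound 1 by 3-chloropyridin-4-yl in place of 1-methylethenyl on a carbonyl carbon. Going by the values given here, the steps that bear on this change are a step that the two limits leave unreadable from compound 1 to compound 2 and a step that the two limits leave unreadable from compound 1 to compound 3; both have limits at either end, so neither can be read, and the same holds for a step that the two limits leave unreadable from compound 2 to compound 3. With nothing readable in this assay, the expected result is a step that the limit leaves unreadable from compound 1 to compound 4, no step beyond the scatter. Compound 4 is accordingly estimated at 30000 nM, between 15000 nM and 60000 nM, most likely reported only as a limit.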

Compound 4, half-maximal effective concentration: > 25000 nM
Compound 4: only a limit was reported; the forecaster's own chance of this, stated with the estimate: 85%; the middle value lies beyond the limit too.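

The steps to compound 4 from compound 1, compound 2 and compound 3 cannot be read, since all four compounds stand at a limit: the limit of > 25000 nM in this assay, at which 4 of the 4 values shown sit.

The compounds shown leave open how far apart these four actually lie, and whether any group on the carbonyl carbon would give a number rather than a limit.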